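The source may hold more compounds than are shown below. What is called first, only, known or untested is meant among the compounds shown, and "the series" means these compounds.

Of the compounds shown here, three have been measured, all sharing one core, in a functional assay on SK-MEL-2 cells (Homo sapiens) for inhibition; on this read-out higher numbers stand for weaker inhibition of growth and lower numbers for stronger inhibition of growth. Compound 1, `COc1cc(/C=C/C(=O)c2cccc(-n3cc(-c4ccc(Cl)cc4)[nH]c3=O)c2)cc(OC)c1OC`, gives 3440 nM in this assay. Compound 2, `O=C(/C=C/c1cccc(O)c1)c1cccc(-n2cc(-c3ccccc3)[nH]c2=O)c1`, gives 8260 nM in this assay. Compound 3, `COc1ccc(-c2cn(-c3cccc(C(=O)/C=C/c4ccc(O)c(OC)c4)c3)c(=O)[nH]2)cc1`, gives 5540 nM in this assay. Compound 1 therefore has the smallest number of the three, but only its gap to compound 2 lies beyond the usual scatter of repeated measurements; compound 3 sits within that scatter of compound 1, so the two cannot be told apart on these numbers.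

Compound 4, `COc1cc(/C=C/C(=O)c2cccc(-n3cc(-c4cc(OC)c(OC)c(OC)c4)[nH]c3=O)c2)cc(OC)c1OC`, has not yet been measured. It differs from compound 1 in one place: 3,4,5-trimethoxyphenyl in place of 4-chlorophenyl on an aromatic carbon. For the measured compounds named here, no pair of measured compounds differs by this same change, so nothing among the three measured numbers says how large a step to expect, and the estimate rests on compound 1 alone. From compound 1 to compound 4 the expected step in this assay is a 1.1-fold lower number from compound 1 to compound 4 (0.06 log units; within the scatter), which is no more than the scatter would hide, in either direction. Compound 4 is therefore expected to give about 3000 nM in this assay, most plausibly between 1000 nM and 9000 nM.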

Compound 4, concentration for 50% growth inhibition: 3020 nM
The estimate for compound 4 lay 1.0-fold (0.00 log units) below the measured number, within the range that was stated.
By their numbers in this assay, from the lowest: compounds 4, 1, 3 and 2 (each within the scatter of the next, the first and the last beyond it).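

In this assay, placing 3,4,5-trimethoxyphenyl in place of 4-chlorophenyl on an aromatic carbon of the five-membered aromatic ring gives a 1.1-fold lower number from compound 1 to compound 4 (0.06 log units; within the scatter), the first step read at this position. The entering group has 12 heavy atoms against 7 and 3 hydrogen-bond acceptors against 0, yet compound 1 and compound 4 cannot be told apart on these numbers, so in this pair a substantial change of substituent leaves the read-out within the scatter. No measurement at hand explains why the two compounds read alike.

This is a single pair, and compound 2 and compound 3 also carry different groups at this position but differ elsewhere as well, so they cannot show whether the result holds with another group on the far side of the molecule. On these data alone, it also remains open whether the number would stay put with a group of another kind here, such as an aminomethyl group or a carboxylic acid on the phenyl ring, or a straight alkyl chain in place of that ring.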